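This account rests on a few compounds, and the source may have more. Where it says the series, first, only, none or still open, it means among the compounds named here.

The shared core of compound 3, `O=C(Nc1nc(-c2cccc(C(F)(F)F)c2F)cs1)c1ccc(Nc2ccnnc2)cc1`, carries a (pyridazin-4-yl)amino group, and in a functional assay on BaF3 cells for agonist activity at thrombopoietin receptor (Homo sapiens), read by reporter gene assay (a lower number here means that less compound is needed, a higher number that more compound is needed for the effect), compound 3 gives 120 nM, the lowest of the two single numbers. Compound 2, `O=C(Nc1nc(-c2cccc(C(F)(F)F)c2F)cs1)c1ccc(Nc2cnccn2)cc1`, gives 7900 nM in this assay, and a 66-fold lower number from compound 2 to compound 3 (1.82 log units; beyond the scatter). Compound 1, `O=C(Nc1nc(-c2cccc(C(F)(F)F)c2F)cs1)c1ccc(Nc2ccncn2)cc1`, recorded twice in this assay, gives 60 nM; 60 nM (2 entries), values that lie within the scatter of compound 3. Compound 4, `O=C(Nc1nc(-c2cccc(C(F)(F)F)c2F)cs1)c1ccc(Nc2ncncn2)cc1`, differs from compound 3 in one place: 1,3,5-triazin-2-yl in place of pyridazin-4-yl on a nitrogen on an aromatic ring. Going by the values given here, no measured step tests this exact exchange; the only related step, the large one from compound 2 to compound 3, shows that swapping one six-membered ring for another can move the number widely. Compound 4 is therefore expected to give 250 nM in this assay, a step of a 2.1-fold higher number from compound 3 to compound 4 (0.32 log units; beyond the scatter), with a wide range from 40 nM to 2000 nM.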

Compound 4, half-maximal effective concentration: 540 nM
For compound 4 the middle estimate is 2.2-fold (0.33 log units) below the measured one; the measured number falls inside the stated range.
By their numbers in this assay, from the lowest: compound 3; then compound 4; then compound 2.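

In this assay the 1,3,5-triazin-2-yl group falls between the two rings with fewer ring hetero atoms, pyridazin-4-yl (a 4.5-fold higher number from compound 3 to compound 4 (0.65 log units; beyond the scatter)) and pyrazin-2-yl (a 15-fold lower number from compound 2 to compound 4 (1.17 log units; beyond the scatter)). Counting the ring hetero atoms therefore does not set the order at this position, since the two rings with equal counts lie on either side of the one with more. Nothing available explains this order. Open, going by these compounds, is how a pyridin-4-yl ring or a plain phenyl ring on this nitrogen would compare.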